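The source may report more compounds than this note shows. Statements on the series, on what has been measured and on what is new or still open speak of the compounds shown alone.

The compounds measured so far in a functional assay on A549 cells (Homo sapiens) for inhibition, read by sulforhodamine B assay, with a stated time of 48 h; on this read-out higher numbers stand for weaker inhibition of growth and lower numbers for stronger inhibition of growth:

Compound 1, `COC(=O)[C@@]1(C)CCC=C2[C@@H]1CC[C@@H](C)[C@]2(C)Cc1c[nH]c2c(Cl)cccc12`: 22000 nM
Compound 2, `COC(=O)[C@@]1(C)CCC=C2[C@@H]1CC[C@@H](C)[C@]2(C)Cc1c(C)[nH]c2ccc(Cl)cc12`: 17000 nM
Compound 3, `COC(=O)[C@@]1(C)CC[C@@H]2C3=C1CC[C@@H](C)[C@]3(C)Cc1c2[nH]c2ccccc12`: 4600 nM

On these numbers compound 3 stands lowest, and its distances to compound 2 and to compound 1 are both beyond the scatter, so it is the strongest growth inhibitor of the three in this assay. Compound 4, `COC(=O)[C@@]1(C)CC[C@@H]2C3=C1CC[C@@H](C)[C@]3(C)Cc1c2[nH]c2ccc(OC)cc12`, differs from compound 3 in one place: methoxy in place of hydrogen on an aromatic carbon. Among the compounds with values here, no measured pair shows this change, so nothing in the data fixes its size. Compound 4 is therefore expected to stay close to compound 3, with a step from a 1.0-fold lower number from compound 3 to compound 4 (0.01 log units; within the scatter) that is not beyond the scatter. Compound 4 is estimated at 4500 nM, with a range from 1500 nM to 14000 nM.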

Compound 4, concentration for 50% growth inhibition: 7700 nM
The estimate for compound 4 lay 1.7-fold (0.23 log units) below the measured number; measured number inside the range.
By their numbers in this assay, from the lowest: compounds 3 and 4 (each within the scatter of the next); then compounds 2 and 1 (each within the scatter of the next).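

In this assay, methoxy in place of hydrogen on an aromatic carbon, meta to a fused ring and para to a fused ring, gives a 1.7-fold higher number from compound 3 to compound 4 (0.22 log units; within the scatter). Within the data shown here, this is the first pair that differs in one place, and it shows that this position of the shared core accepts methoxy with the numbers staying within the scatter of each other. No measurement at hand offers a reason for this result. On these data alone, whether an amine, a carboxylic acid or a longer chain such as ethoxy at this same position would take the number beyond the scatter remains open.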